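This account rests on a few compounds, and the source may have more. Where it says the series, first, only, none or still open, it means among the compounds named here.

Going by the values given here, compound 2 `COc1ccc(-c2cnc(C(=O)CCCCCCc3ccccc3)o2)cc1` sits at the top of the three numbers measured so far: in an assay (Rattus norvegicus) for inhibition of Fatty-acid amide hydrolase 1 (Homo sapiens) (on this read-out lower numbers stand for stronger inhibition and higher numbers for weaker inhibition), compound 2 gives 100 nM. Its two neighbours share the same core and differ only in the group on the aromatic ring. Compound 1 `COC(=O)c1ccc(-c2cnc(C(=O)CCCCCCc3ccccc3)o2)cc1` gives 40 nM, and compound 3 `O=C(CCCCCCc1ccccc1)c1ncc(-c2ccc(C(=O)C(F)(F)F)cc2)o1` gives 65 nM. The step of a 2.5-fold higher number from compound 1 to compound 2 (0.40 log units; beyond the scatter) is the only one that reaches beyond the scatter; the steps of a 1.6-fold higher number from compound 1 to compound 3 (0.21 log units; within the scatter) and a 1.5-fold lower number from compound 2 to compound 3 (0.19 log units; within the scatter) stay within it.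

Compound 4 `CNC(=O)c1cnc(C(=O)CCCCCCc2ccccc2)o1` is not yet measured. It differs from compound 2 in one place: methylcarbamoyl in place of 4-methoxyphenyl on an aromatic carbon. The new group sits on an aromatic carbon of a five-membered aromatic ring with 1 nitrogen and 1 oxygen, next to the ring oxygen.

None of the three measured steps bears directly on this change. Each of them swaps one group for another on the aromatic carbon of the 4-methoxyphenyl ring, which remains in every measured compound; here that whole ring leaves and a far smaller methylcarbamoyl enters. The measured steps therefore give no guide to size or direction, only the note that the known compounds all keep that ring. With no anchor, the expected step of a 10-fold higher number from compound 2 to compound 4 (1.00 log units; beyond the scatter) from compound 2 to compound 4 is a loss, given a wide range. The estimate for compound 4 is 1000 nM, expected to lie between 200 nM and 8000 nM.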

Compound 4, inhibition constant: 7 nM
For compound 4 the middle estimate is 140-fold (2.15 log units) above the measured one, and the stated range ends above it.
By their numbers in this assay, from the lowest: compound 4; then compounds 1, 3 and 2 (each within the scatter of the next, the first and the last beyond it).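

In this assay, the step of a 14-fold lower number from compound 2 to compound 4 (1.15 log units; beyond the scatter) shows that the aromatic carbon next to the ring oxygen does not need an aromatic ring to give a low number: methylcarbamoyl has no ring and fewer heavy atoms than the 4-methoxyphenyl it replaces. The earlier compounds shown here could not show this, since all of them keep that six-membered ring and differ only in the group it carries, and the largest step among them is a 2.5-fold higher number from compound 1 to compound 2 (0.40 log units; beyond the scatter), so replacing the whole group moves the number much further than any of those swaps. No measurement given here explains the size of this step.

This single change removes the ring and brings in a carbonyl and an amide hydrogen all at once, so the compounds shown leave open which of these matters, and whether any small group on this carbon would do as well. A nitrile, a carboxylic acid or a dimethylcarbamoyl group at this place, the last keeping the carbonyl without the amide hydrogen, would begin to separate these possibilities.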